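The source may report more compounds than this note shows. Statements on the series, on what has been measured and on what is new or still open speak of the compounds shown alone.

Measured so far:
Compound 1 `CCCCC#Cc1cn(C/C=C\CN2C(=O)c3ccccc3C2=O)c(=O)[nH]c1=O` gives 100000 nM in a functional assay on CCRF-CEM cells (Homo sapiens) for antiproliferative activity, read by MTT assay, with a stated time of 3 days; on this read-out higher numbers stand for weaker inhibition and lower numbers for stronger inhibition.
Compound 2 `CCCCCCC#Cc1cn(C/C=C/CN2C(=O)c3ccccc3C2=O)c(=O)[nH]c1=O` gives 28000 nM in this assay.
Compound 3 `O=C1c2ccccc2C(=O)N1C/C=C\Cn1cc(C#Cc2ccc(Br)cc2)c(=O)[nH]c1=O` gives 80000 nM in this assay.

Compound 2 holds the lowest number of the three, with compound 3 and compound 1 both standing beyond the scatter above it. Compound 4 `CCCCC#Cc1cn(C/C=C/CN2C(=O)c3ccccc3C2=O)c(=O)[nH]c1=O` differs from compound 2 by hydrogen in place of ethyl on a saturated chain carbon, four bonds along the chain from a triple-bonded carbon. For the measured compounds named here, the only measured single-point step, a 1.3-fold lower number from compound 1 to compound 3 (0.10 log units; within the scatter), concerns the group on the triple-bonded carbon and stayed within the scatter, so it offers weak guidance for a shortening of the chain. Compound 1, which carries the same butyl chain as compound 4, reads far weaker than compound 2, and that gap suggests some loss. Compound 4 is therefore expected to show a 2.1-fold higher number from compound 2 to compound 4 (0.33 log units; beyond the scatter), landing at an estimated 60000 nM within 20000 nM to 150000 nM.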

Compound 4, half-maximal inhibitory concentration: 192000 nM
Estimate against measurement, compound 4: 3.2-fold (0.51 log units) below; the measured number lies above the stated range.
By their numbers in this assay, from the lowest: compound 2; then compounds 3, 1 and 4 (each within the scatter of the next, the first and the last beyond it).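

Hydrogen in place of ethyl on the saturated chain carbon brings a 6.9-fold higher number from compound 2 to compound 4 (0.84 log units; beyond the scatter), the first single-place step beyond the scatter, so the length of this chain counts in this assay. The geometry of the double bond shows no such effect with the shorter chain, since a 1.9-fold higher number from compound 1 to compound 4 (0.28 log units; within the scatter) stays within the scatter. This reading rests on a clean comparison: the fact that compounds 1 and 4 differ only in the configuration as drawn

From the compounds shown here alone, whether a longer chain would lower the number further remains open, as does the effect of an amine or a carboxylic acid at the chain end.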